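Ring Swap on the Thiocarbonyl Carbon of Two Cores

The compounds below may be only part of what the source reports. "The series", "measured", "known", "first", "only" and "open" are said of these compounds alone.

Compound 1 `O=c1c(SC(=S)N2CCCCC2)coc2ccccc12` gives 5800 nM in a functional assay on HEp-2 cells (Homo sapiens) for antiproliferative activity, read by MTT assay, with a stated time of 72 h; a higher number here means a weaker inhibitor, a lower number a stronger inhibitor.
Compound 2 `O=c1cc(CSC(=S)N2CCCCC2)oc2cc(Cl)ccc12` gives 1600 nM in this assay.
Compound 3 `O=c1cc(CSC(=S)N2CCCC2)oc2cc(Cl)ccc12` reaches only a limit of the assay in this assay, > 40000 nM.

Of the two numbers recorded, compound 1 sits at the higher one and compound 2 at the lower, the gap lying beyond the scatter. How the core of compound 1 differs from the core of compound 2 is not broken down here.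

Within the core of compound 2, the change pyrrolidin-1-yl in place of piperidin-1-yl on a thiocarbonyl carbon produced an at least 25-fold higher number from compound 2 to compound 3 (1.39 log units; beyond the scatter), the number for compound 3 resting at the limit of > 40000 nM in this assay, at which 1 of the 3 values shown sits.

Compound 4 `O=c1c(SC(=S)N2CCCC2)coc2ccccc12` carries the same change on the core of compound 1: pyrrolidin-1-yl in place of piperidin-1-yl on a thiocarbonyl carbon. Since the place of the change is the same in both pairs, the step is expected to be of like size, and because compound 1 already starts at 5800 nM, compound 4 is expected to come out far weaker still, with a 17-fold higher number from compound 1 to compound 4 (1.24 log units; beyond the scatter).

Compound 4 is estimated at 100000 nM, between 30000 nM and 400000 nM.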

Compound 4, half-maximal inhibitory concentration: 7400 nM
The estimate for compound 4 lay 14-fold (1.13 log units) above the measured number; the measured number lies below the stated range.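

On the core of compound 1, the change from piperidin-1-yl to pyrrolidin-1-yl gives, in this assay, a 1.3-fold higher number from compound 1 to compound 4 (0.11 log units; within the scatter), so compound 1 and compound 4 cannot be told apart here. The large step seen on the core of compound 2 therefore does not carry over to the core of compound 1, and the size of this change depends on the core in these two pairs: the same change on two cores in this assay, an at least 25-fold higher number (1.39 log units; beyond the scatter) from compound 2 to compound 3 and a 1.3-fold higher number (0.11 log units; within the scatter) from compound 1 to compound 4, at least 19-fold (1.29 log units) apart, beyond the scatter of two such steps Compound 3 stands at a limit of the assay, > 40000 nM, and the two pairs do not show which feature of the cores goes with the gap or how the change would behave on any third core.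

The compounds shown leave open how each core would respond to other amines on the thiocarbonyl carbon, such as morpholine or dimethylamine. Also open, from the compounds shown here alone, is how the core of compound 2 would respond without its chloro group, a comparison that would separate that group from the rest of the difference between the cores.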